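The compounds below may be only part of what the source reports. "The series", "measured", "known", "first", "only" and "open" are said of these compounds alone.

Measured compounds:
Compound 1 `CC(C)[C@H](NC(=O)COc1cccc2ccccc12)C(=O)N[C@@H](CC(=O)O)C(=O)CSC1=NCCS1`: in a functional assay on Jurkat cells (Homo sapiens) for inhibition (on this read-out higher numbers stand for weaker inhibition and lower numbers for stronger inhibition), compound 1 gives > 200000 nM, which is a limit of the assay.
Compound 2 `Cc1cc(C)nc(SCC(=O)[C@H](CC(=O)O)NC(=O)[C@@H](NC(=O)COc2cccc3ccccc23)C(C)C)n1`: in this assay compound 2 gives > 200000 nM, which is a limit of the assay.

Compound 2 therefore stands only at a limit; both values shown sit at the limit of > 200000 nM in this assay, at which 2 of the 2 values shown sit. For the measured compounds named here, the single measured step, a step that the two limits leave unreadable from compound 1 to compound 2, is a change on the same sulfur, but the two limits leave its size and direction unreadable.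

Compound 3 `CC(C)[C@H](NC(=O)COc1cccc2ccccc12)C(=O)N[C@@H](CC(=O)O)C(=O)CSc1nccc(C(F)(F)F)n1` carries 4-(trifluoromethyl)pyrimidin-2-yl in place of 4,6-dimethylpyrimidin-2-yl on a sulfur. Going by the values given here, the one measured step bears on this position, yet it gives no readable size, so no size of step can be taken from it for this assay; the change is expected to leave compound 3 at or near the limit, with the estimated step of a number no higher from compound 2 to compound 3 (the limit leaves the size open) not resolvable beyond the scatter. For compound 3 in this assay the estimate is 200000 nM, in a range from 50000 nM to 1000000 nM, most likely reported again as a limit.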

Compound 3, half-maximal inhibitory concentration: > 200000 nM
Compound 3: only a limit was reported; the forecaster's own chance of this, stated with the estimate: 75%; the middle value sits exactly at the limit.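

No step can be read among compound 1, compound 2 and compound 3 in this assay, each value being a limit of the assay: the limit of > 200000 nM in this assay, at which 3 of the 3 values shown sit.

The compounds shown leave open whether the group on the sulfur changes inhibition in this assay at all, and by how much.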